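This account rests on a few compounds, and the source may have more. Where it says the series, first, only, none or still open, it means among the compounds named here.

Measured in a functional assay on HeLa cells (Homo sapiens) for antiproliferative activity, read by MTT assay, with a stated time of 72 h; a lower number here means a stronger inhibitor, a higher number a weaker inhibitor:
- Compound 1 `COc1cc(-n2ncnc2-c2ccc(C)cc2)cc(OC)c1OC`: 250 nM
- Compound 2 `COc1cccc(-c2ncnn2-c2cc(OC)c(OC)c(OC)c2)c1`: > 10000 nM (a limit)
- Compound 3 `CCOc1ccc(-c2ncnn2-c2cc(OC)c(OC)c(OC)c2)cc1Cl`: 6 nM

Compound 3 holds the lower of the two exact numbers, and its gap to compound 1 lies beyond the scatter. Compound 4 `COc1cc(-n2ncnc2-c2ccc(Cl)c(Cl)c2)cc(OC)c1OC` has chloro in place of ethoxy on an aromatic carbon, para to a large group and ortho to a chloro group: chloro in place of ethoxy on an aromatic carbon. Going by the values given here, the one measured step, an at least 40-fold higher number from compound 1 to compound 2 (1.60 log units; beyond the scatter), is a different change, but it is large and shows that one swapped group can matter greatly here. Compound 1 also lacks ethoxy and gives 250 nM, so a higher number beyond the scatter is expected in this assay. The expected step is a 25-fold higher number from compound 3 to compound 4 (1.40 log units; beyond the scatter). For compound 4 the estimate is 150 nM, with an expected range of 20 nM to 1500 nM.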

Compound 4, half-maximal inhibitory concentration: > 10000 nM
Compound 4: only a limit was reported; the forecaster's own chance of this, stated with the estimate: 10%; at least 66-fold (1.82 log units) between middle value and limit.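

In this assay, compound 4 is reported only as a limit, > 10000 nM. Chloro in place of ethoxy, para to a large group and ortho to a chloro group, gives an at least 1600-fold higher number from compound 3 to compound 4 (3.22 log units; beyond the scatter), so activity depends heavily on the group at this one position, and 3,4-dichlorophenyl in place of 4-methylphenyl gives an at least 40-fold higher number from compound 1 to compound 4 (1.60 log units; beyond the scatter). The step between compound 2 and compound 4 cannot be read: the limit of > 10000 nM in this assay, at which 2 of the 4 values shown sit.

The compounds shown leave open how an amine or a longer chain such as propoxy would behave at this position. They also leave open whether ethoxy would give a similar result without the neighbouring chloro group.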